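Adding a methyl at the amine-bearing carbon of compound 2

The source may report more compounds than this note shows. Statements on the series, on what has been measured and on what is new or still open speak of the compounds shown alone.

Compound 2 `CN(Cc1ccc(C(=O)O)cc1)c1ccc(OCc2c(-c3c(Cl)cccc3Cl)noc2C2CC2)nc1C(F)(F)F` stands highest of the three measured compounds in a functional assay on HEK293 cells for agonist activity at Bile acid receptor (Homo sapiens), read by a luciferase reporter (on this read-out higher numbers stand for larger maximal responses and lower numbers for smaller maximal responses), with 60%. Compound 3 `CN(Cc1ccc(C(=O)NCCS(=O)(=O)O)cc1)c1ccc(OCc2c(-c3c(Cl)cccc3Cl)noc2C2CC2)nc1C(F)(F)F` gives 49% and compound 1 `CN(Cc1cccc(C(=O)O)c1)c1ccc(OCc2c(-c3c(Cl)cccc3Cl)noc2C2CC2)nc1C(F)(F)F` gives 43%. The two measured steps, a number 17 percentage points higher from compound 1 to compound 2 (beyond the scatter) and a number 11 percentage points lower from compound 2 to compound 3 (beyond the scatter), both alter the acid-bearing side of the molecule. Compound 4 `CCN(Cc1ccc(C(=O)O)cc1)c1ccc(OCc2c(-c3c(Cl)cccc3Cl)noc2C2CC2)nc1C(F)(F)F` differs from compound 2 elsewhere: methyl in place of hydrogen on a saturated chain carbon bound to a nitrogen on an aromatic ring. Among the compounds with values here, neither measured step touches that position, so no direct precedent exists; the change is one carbon with no donors or acceptors, and the expectation is a step within or near the scatter. Compound 4 is therefore estimated at 55%, between 35% and 75%, a step of a number 5 percentage points lower from compound 2 to compound 4 (within the scatter) expected.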

Compound 4, largest response reached (reported as efficacy), in percent of the reference or control that the assay uses: 43%
Compound 4: the middle estimate sits 12 percentage points above what was measured; the range from low to high includes it.
By their numbers in this assay, from the lowest: compounds 1, 4 and 3 (each within the scatter of the next); then compound 2.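

In this assay, methyl in place of hydrogen on a saturated chain carbon bound to a nitrogen on an aromatic ring gives a number 17 percentage points lower from compound 2 to compound 4 (beyond the scatter) and so exceeds the scatter. Within the data shown here, this is the first measured change away from the acid-bearing side, and it shows that the maximal response also depends on this position, even with one added carbon. No evidence at hand explains the step.

Going by these compounds, whether a propyl or cyclopropyl group at this carbon would lower the response further remains open. So does whether methyl would have a similar effect on compound 3.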